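Compound 4 against a series held at the limit

The compounds below may be only part of what the source reports. "The series", "measured", "known", "first", "only" and "open" are said of these compounds alone.

In a functional assay on A549 cells (Homo sapiens) for antiproliferative activity, read by MTT assay, with a stated time of 48 h (a lower number here means a stronger inhibitor, a higher number a weaker inhibitor), compound 1 `Cn1c(N)c(-c2nc3ccccc3[nH]2)c2nc(C#N)c(C#N)nc21` gives > 50000 nM, which is a limit and not a number. Compound 2 `CN(C)CCn1c(N)c(-c2nc3ccccc3[nH]2)c2nc(C#N)c(C#N)nc21` gives > 50000 nM, again a limit. Compound 3 `N#Cc1nc2c(-c3nc4ccccc4[nH]3)c(N)n(CCN3CCCC3)c2nc1C#N` gives > 50000 nM, also a limit, so its position is known only as a limit. For the measured compounds named here, the whole series so far stands at the limit of > 50000 nM in this assay, at which 3 of the 3 values shown sit.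

Compound 4 `CN1CCN(CCn2c(N)c(-c3nc4ccccc4[nH]3)c3nc(C#N)c(C#N)nc32)CC1` differs from compound 3 at one place: 4-methylpiperazin-1-yl in place of pyrrolidin-1-yl on a saturated chain carbon, two bonds along the chain from an aromatic nitrogen.

The closest measured change is a step that the two limits leave unreadable from compound 2 to compound 3, which swaps one group at the same chain carbon. Two further changes bear on the same chain: a step that the two limits leave unreadable from compound 1 to compound 2 and a step that the two limits leave unreadable from compound 1 to compound 3. None of these has a readable size, so they give no direction for the new group. None of the three side chains has yet brought a value clear of the limit in this assay, and no step beyond the scatter is expected. The expected outcome is a number no higher from compound 3 to compound 4 (the limit leaves the size open), and another report of a limit is the most likely result. The estimated value for compound 4 is 50000 nM, with an expected range from 20000 nM to 100000 nM.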

Compound 4, half-maximal inhibitory concentration: 40500 nM
Compound 4: the middle estimate sits 1.2-fold (0.09 log units) above what was measured; the measured number falls inside the stated range.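

Of the four compounds, only compound 4 has a number and not a limit in this assay: the limit of > 50000 nM in this assay, at which 3 of the 4 values shown sit.

At the saturated chain carbon, two bonds along the chain from an aromatic nitrogen, 4-methylpiperazin-1-yl in place of pyrrolidin-1-yl gives an at least 1.2-fold lower number from compound 3 to compound 4 (0.09 log units; that floor lies within the scatter), and 4-methylpiperazin-1-yl in place of dimethylamino gives an at least 1.2-fold lower number from compound 2 to compound 4 (0.09 log units; that floor lies within the scatter). On the saturated chain carbon bound to an aromatic nitrogen, (4-methylpiperazin-1-yl)methyl in place of hydrogen gives an at least 1.2-fold lower number from compound 1 to compound 4 (0.09 log units; that floor lies within the scatter). The steps among compound 1, compound 2 and compound 3 cannot be read, while these three can be read, but only as floors that lie within the scatter, and none of them establishes a real gain for the 4-methylpiperazin-1-yl side chain.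

From the compounds shown here alone, how far compound 4 actually lies from compound 1, compound 2 and compound 3 stays open, as does whether the methyl or the second ring nitrogen of the new group has any part in the number. Going by these compounds, it is also open whether morpholin-4-yl, an unsubstituted piperazin-1-yl or a longer chain at this place would give a number at all.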